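The source may report more compounds than this note shows. Statements on the series, on what has been measured and on what is new or still open speak of the compounds shown alone.

Compound 2 `COc1ccc(CNc2nc(/C=C/c3cc(OC)c(OC)c(OC)c3)nc3ccsc23)cc1` and compound 3 `COc1cc(/C=C/c2nc(NCc3ccncc3)c3sccc3n2)cc(OC)c1OC` share one core, and compound 1 `COc1cc(/C=C/c2nc(Nc3ccc(O)cc3)c3sccc3n2)cc(OC)c1OC` differs from compound 2 at another point. In a functional assay on L02 cells (Homo sapiens) for inhibition, read by Griess assay, with stated times of 1 h and 24 h (on this read-out higher numbers stand for weaker inhibition and lower numbers for stronger inhibition), compound 2 gives only a limit of the assay, > 1000000 nM. In this assay compound 1 likewise gives only a limit, > 1000000 nM. The step that the two limits leave unreadable from compound 1 to compound 2 therefore cannot be read, and the limit of > 1000000 nM in this assay, at which 2 of the 2 values shown sit, is all that these two values carry. The change from compound 2 to compound 3 is pyridin-4-yl in place of 4-methoxyphenyl on a saturated chain carbon bound to a nitrogen on an aromatic ring. Going by the values given here, no measured step touches this change, and the one step on record is itself unreadable, so neither a size nor a direction can be drawn for it in this assay. With both measured values sitting at the limit, compound 3 is expected to sit there too, a step of a number no higher from compound 2 to compound 3 (the limit leaves the size open). The estimate for compound 3 in this assay is 1000000 nM, with a range from 300000 nM to 5000000 nM.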

Compound 3, half-maximal inhibitory concentration: 374000 nM
Beside the measured number, compound 3's estimate is 2.7-fold (0.43 log units) above it; the measured number falls inside the stated range.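

In this assay, going by these compounds alone, putting pyridin-4-yl in place of 4-methoxyphenyl on a saturated chain carbon bound to a nitrogen on an aromatic ring gives the first readable change at this site: an at least 2.6-fold lower number from compound 2 to compound 3 (0.42 log units; beyond the scatter). Measured against the other compound, (pyridin-4-yl)methyl in place of 4-hydroxyphenyl on the same nitrogen gives an at least 2.6-fold lower number from compound 1 to compound 3 (0.42 log units; beyond the scatter). From the compounds shown here alone, this shows that the group on this nitrogen can bring the read-out inside the measurable range, towards stronger inhibition, although the full size of both steps stays open: the limit of > 1000000 nM in this assay, at which 2 of the 3 values shown sit.

The step from compound 2 to compound 3 adds a ring nitrogen and removes a methoxy group together, so a plain phenyl group at this place would be needed to tell these two changes apart. Going by these compounds, how pyridin-3-yl, or a longer chain carrying the pyridin-4-yl ring, would read also remains open.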